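A few compounds are considered here, and "the series" means these few. Any claim that something is new, unique, unknown or untested is made for them only; others in the source may bear on it.

Measured so far:
compound 1 `C=CC(=O)Nc1cccc(-n2cnc3cnc(Nc4ccc(N5CCN(S(C)(=O)=O)CC5)cc4OC)nc32)c1` — 38600 nM
compound 2 `C=CC(=O)Nc1cccc(-n2cnc3cnc(Nc4ccc(N5CCN(C)CC5)cc4OC)nc32)c1` — 13200 nM

Among the compounds with values here, compound 1 stands at the highest of the two numbers in a functional assay on Ramos cells (Homo sapiens) for antiproliferative activity, read by CCK-8 assay, with a stated time of 48 h; on this read-out lower numbers stand for stronger inhibition and higher numbers for weaker inhibition; its nearest neighbour is compound 2, and the step of a 2.9-fold lower number from compound 1 to compound 2 (0.47 log units; beyond the scatter) is the only measured step, a methyl in place of methylsulfonyl on an amine nitrogen in a ring.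

Compound 3 `C=CC(=O)Nc1cccc(-n2cnc3cnc(Nc4ccc(N5CCN(S(C)(=O)=O)CC5)cc4)nc32)c1` is not yet measured. It differs from compound 1 by hydrogen in place of methoxy on an aromatic carbon, on an aromatic carbon of a six-membered aromatic ring of carbon only, ortho to a large group and meta to the 4-(methylsulfonyl)piperazin-1-yl group. Within the data shown here, the one measured step concerns a different position and a different kind of group, so no measured step bears on this change. With nothing to anchor a direction, no step beyond the scatter is expected from compound 1 to compound 3, and the estimate is held close to compound 1 with a wide range. Compound 3 is therefore estimated at 45000 nM, between 15000 nM and 140000 nM, which means an expected step of a 1.2-fold higher number from compound 1 to compound 3 (0.07 log units; within the scatter).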

Compound 3, half-maximal inhibitory concentration: > 40000 nM
Compound 3: no number, only a limit; the forecaster's own chance of this, stated with the estimate: 25%; the middle value is on the limit's open side.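

In this assay compound 3 gives only a limit and not a number, > 40000 nM. Hydrogen in place of methoxy on this aromatic carbon, ortho to a large group, gives an at least 1.0-fold higher number from compound 1 to compound 3 (0.01 log units; that floor lies within the scatter), so the change is bounded on one side only: no loss can be claimed for removing the methoxy, and a larger loss is not excluded. This is the first reading at this position, and it is a limit: the limit of > 40000 nM in this assay, at which 1 of the 3 values shown sits.

The compounds shown leave open whether the methoxy counts for anything at this position when the 4-(methylsulfonyl)piperazin-1-yl group gives way to the methyl-bearing piperazine of compound 2, where the same change could start from a value lying further from the limit. They also leave open how an ethoxy, a fluorine or an amine on this aromatic carbon would read in this assay, since methoxy and hydrogen are the only two groups shown there.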